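A Nitro Group Added to the Ring of Compound 3

A few compounds are considered here, and "the series" means these few. Any claim that something is new, unique, unknown or untested is made for them only; others in the source may bear on it.

Compound 3 `Cc1ccc(S(=O)(=O)NC(=O)Nc2ccccc2C(=O)/C=C/c2cccc(O)c2)cc1` gives 39.3 ug/mL in an ADME assay on the whole organism for cytotoxicity, with Artemia salina as the target, with a stated time of 24 h (a higher number here means that more compound is needed for the effect, a lower number that less compound is needed), a number that lies beyond the scatter from compound 1 but within the scatter of compound 2. Compound 1 `Cc1ccc(/C=C/C(=O)c2ccccc2NC(=O)NS(=O)(=O)c2ccc(C)cc2)cc1` gives 15.3 ug/mL in this assay, and compound 2 `Cc1ccc(S(=O)(=O)NC(=O)Nc2ccccc2C(=O)/C=C/c2ccccc2O)cc1` gives 32.3 ug/mL in this assay. The measured steps are all modest: a 2.1-fold higher number from compound 1 to compound 2 (0.32 log units; beyond the scatter) and a 2.6-fold higher number from compound 1 to compound 3 (0.41 log units; beyond the scatter), while a 1.2-fold higher number from compound 2 to compound 3 (0.09 log units; within the scatter) stays within the scatter. Compound 4 `Cc1ccc(S(=O)(=O)NC(=O)Nc2ccccc2C(=O)/C=C/c2cc(O)ccc2[N+](=O)[O-])cc1` differs from compound 3 by a single change: nitro in place of hydrogen on an aromatic carbon. Among the compounds with values here, no measured step introduces a nitro group, so none bears directly on this change; the steps that alter the same ring moved the numbers only modestly, and the closest of them, from compound 2 to compound 3, did not leave the scatter. The account therefore expects a 1.0-fold higher number from compound 3 to compound 4 (0.01 log units; within the scatter) to stay within the scatter, with no firm direction. The estimate for compound 4 in this assay is 40 ug/mL, with a range from 15 ug/mL to 105 ug/mL.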

Compound 4, concentration for half-maximal effect: 18.3 ug/mL
Estimate against measurement, compound 4: 2.2-fold (0.34 log units) above, within the range that was stated.
By their numbers in this assay, from the lowest: compounds 1, 4, 2 and 3 (each within the scatter of the next, the first and the last beyond it).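

In this assay, nitro in place of hydrogen, ortho to a large group and para to a hydroxy group, gives a 2.1-fold lower number from compound 3 to compound 4 (0.33 log units; beyond the scatter) and so shows that a change at this ring carbon can move the number beyond the scatter, in the opposite direction to the steps from compound 1 to the two hydroxy compounds. The added nitro also removes the separation that compound 3 had from compound 1, as the record now reads a 1.2-fold higher number from compound 1 to compound 4 (0.08 log units; within the scatter) and a 1.8-fold lower number from compound 2 to compound 4 (0.25 log units; within the scatter) and both of these lie within the scatter. Nothing in the data given accounts for this step.

From the compounds shown here alone, whether the step belongs to nitro itself or to any group on this carbon stays open, and an amine or a carboxylic acid there would separate the two readings. Also open, going by these compounds, is whether the hydroxy group para to it matters, which a 2-nitrophenyl group without that hydroxy would test.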